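Removing a Methoxy Group from Compound 2

This account rests on a few compounds, and the source may have more. Where it says the series, first, only, none or still open, it means among the compounds named here.

Compound 1 `COc1ccc(N/C=C\C(=O)c2nc(-c3ccc(F)cc3)n3ccccc23)cc1` carries a fluoro on one of its aromatic rings. In a functional assay on HCT-116 cells (Homo sapiens) for cytotoxicity, read by MTT assay, with a stated time of 48 h (a higher number here means a weaker inhibitor, a lower number a stronger inhibitor), compound 1 gives only a limit, > 30000 nM. Compound 2 `COc1ccc(N/C=C\C(=O)c2nc(-c3ccc(OC)cc3)n3ccccc23)cc1` differs from it by methoxy in place of fluoro on an aromatic carbon. In this assay compound 2 likewise gives only a limit, > 30000 nM. The step that the two limits leave unreadable from compound 1 to compound 2 cannot be read, since the limit of > 30000 nM in this assay, at which 2 of the 2 values shown sit, holds both values shown. Compound 3 `COc1ccc(N/C=C\C(=O)c2nc(-c3ccccc3)n3ccccc23)cc1` differs from compound 2 by hydrogen in place of methoxy on an aromatic carbon, the same difference read one bond further out being 4-methoxyphenyl to phenyl. Among the compounds with values here, the only measured step gives no readable size to carry over, and both neighbours sit at the limit. The expected step that the limit leaves unreadable from compound 2 to compound 3 is therefore of no readable size, and compound 3 is expected to remain at or near that limit. The estimate for compound 3 in this assay is 40000 nM, ranging from 15000 nM to 150000 nM.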

Compound 3, half-maximal inhibitory concentration: 7010 nM
For compound 3 the middle estimate is 5.7-fold (0.76 log units) above the measured one; measured number below the stated range.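

In this assay, this place on the six-membered aromatic ring, para to a large group, turns out to matter for the read-out: removing the substituent gives an at least 4.2-fold lower number from compound 2 to compound 3 (0.63 log units; beyond the scatter), and an at least 4.2-fold lower number from compound 1 to compound 3 (0.63 log units; beyond the scatter). With hydrogen here, compound 3 gives a measured number, whereas the methoxy of compound 2 and the fluoro of compound 1 gave only limits. Each step therefore fixes only the smallest size it can have, and its full size stays unknown: the limit of > 30000 nM in this assay, at which 2 of the 3 values shown sit.

The step between compound 1 and compound 2 still cannot be read, so methoxy and fluoro cannot be ranked against each other. The compounds shown also leave open whether a methyl, a chloro or an amine at this place would give a measured number, as hydrogen does, or a limit.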